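The compounds below may be only part of what the source reports. "The series", "measured", "known", "first", "only" and "open" are said of these compounds alone.

Compound 1 `O=c1c(-c2nn[nH]n2)c[nH]c2ccccc12` sits at the limit of a functional assay on the whole organism (strain Sprague-Dawley) for inhibition, with Rattus norvegicus as the target; a higher number here means that more compound is needed for the effect, a lower number that less compound is needed: in this assay compound 1 gives > 20 mg/kg, a limit and not a number. For the measured compounds named here, of the three values known, one is this limit, another is a limit as well; only one is a number.

Compound 2 `O=c1c(-c2nn[nH]n2)c[nH]c2ccc(Cl)cc12` carries chloro in place of hydrogen on an aromatic carbon. In this assay compound 2 gives > 25 mg/kg, which is again a limit. The step that the two limits leave unreadable from compound 1 to compound 2 cannot be read, since both ends are limits (the limit of > 20 mg/kg in this assay, at which 1 of the 3 values shown sits, (the limit of > 25 mg/kg in this assay, at which 1 of the 3 values shown sits)).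

Compound 3 `CCc1ccc2[nH]cc(-c3nn[nH]n3)c(=O)c2c1` carries ethyl in place of hydrogen on an aromatic carbon. In this assay compound 3 gives 0.625 mg/kg. The step of an at least 32-fold lower number from compound 1 to compound 3 (1.50 log units; beyond the scatter) is the only readable one, and an at least 40-fold lower number from compound 2 to compound 3 (1.60 log units; beyond the scatter) points the same way.

Compound 4 `CC(C)c1cccc2c(=O)c(-c3nn[nH]n3)c[nH]c12` differs from compound 1 by isopropyl in place of hydrogen on an aromatic carbon. Going by the values given here, the nearest measured step is the ethyl for hydrogen exchange, large and downward; an alkyl group of three carbon atoms at a place ortho to a fused ring and meta to a fused ring has no measured precedent in this set. A downward step is therefore expected, but smaller and less certain than an at least 32-fold lower number from compound 1 to compound 3 (1.50 log units; beyond the scatter). Compound 4 is estimated at 5 mg/kg, with a range of 1 mg/kg to 25 mg/kg, meaning an expected step of an at least 4.0-fold lower number from compound 1 to compound 4 (0.60 log units; beyond the scatter).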

Compound 4, minimum effective dose: 10 mg/kg
For compound 4 the middle estimate is 2.0-fold (0.30 log units) below the measured one; the range from low to high includes it.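

For the compounds shown here, compound 4 carries an isopropyl group on an aromatic carbon, ortho to a fused ring and meta to a fused ring, which gives the shared core a measured number at a place other than the one carrying ethyl in compound 3, so compound 3 is no longer the only compound with a number rather than a limit. In this assay the change reads as an at least 2.0-fold lower number from compound 1 to compound 4 (0.30 log units; that floor lies within the scatter), and this floor alone does not establish a real gain from the isopropyl group at this place, unlike the floor printed for ethyl in compound 3. The step can be read only as a floor because the value for compound 1 is a limit and not a number: the limit of > 20 mg/kg in this assay, at which 1 of the 4 values shown sits.

The compounds shown do not separate the effect of the group from that of the place, as ethyl and isopropyl each appear at one place only, and compounds 3 and 4 differ in both. On these data alone, it remains open how a methyl group, a longer chain, an amine or a carboxylic acid would read at the place ortho to a fused ring and meta to a fused ring.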